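The compounds below may be only part of what the source reports. "The series", "measured", "known", "first", "only" and "open" are said of these compounds alone.

In a functional assay on HepG2 cells (Homo sapiens) for inhibition, read by MTT assay, with a stated time of 48 h (on this read-out higher numbers stand for weaker inhibition and lower numbers for stronger inhibition), compound 3 `COc1ccc(N(C)c2nc(C)nc3ccccc23)cc1OCC[Se]C#N` gives 14 nM, the lowest number of the three measured, against compound 1 `COc1ccc(N(C)c2nc(C)nc3ccccc23)cc1OCCC[Se]C#N` at 1040 nM and compound 2 `COc1ccc(N(C)c2nc(C)nc3ccccc23)cc1OCCCCCC[Se]C#N` at 4890 nM. Compound 4 `COc1ccc(N(C)c2nc(C)nc3ccccc23)cc1C[Se]C#N` carries a different side group: a group of 4 heavy atoms (2 carbon, 1 nitrogen, 1 selenium; no ring) in place of a group of 6 heavy atoms (3 carbon, 1 nitrogen, 1 oxygen, 1 selenium; no ring), on an aromatic carbon, on an aromatic carbon, ortho to a methoxy group. The nearest evidence is the chain steps, a 74-fold lower number from compound 1 to compound 3 (1.87 log units; beyond the scatter) and a 350-fold lower number from compound 2 to compound 3 (2.54 log units; beyond the scatter), both large, and a 4.7-fold higher number from compound 1 to compound 2 (0.67 log units; beyond the scatter), modest. For the measured compounds named here, none of these removes the oxygen on the aromatic ring, so no measured step matches this change directly. With the number this sensitive to the chain, a large step towards a higher number is expected in this assay, estimated as a 14-fold higher number from compound 3 to compound 4 (1.15 log units; beyond the scatter). Compound 4 is estimated at 200 nM, with an expected range of 25 nM to 1500 nM.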

Compound 4, half-maximal inhibitory concentration: 1110 nM
Beside the measured number, compound 4's estimate is 5.6-fold (0.74 log units) below it, within the range that was stated.
By their numbers in this assay, from the lowest: compound 3; then compounds 1 and 4 (each within the scatter of the next); then compound 2.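

In this assay, the group of 4 heavy atoms on the aromatic carbon ortho to a methoxy group does not keep the low number of the oxygen-linked chain (a 79-fold higher number from compound 3 to compound 4 (1.90 log units; beyond the scatter)). It stands level with compound 1 (a 1.1-fold higher number from compound 1 to compound 4 (0.03 log units; within the scatter)) and still gives a lower number than the long chain (a 4.4-fold lower number from compound 2 to compound 4 (0.64 log units; beyond the scatter)), so compound 4 goes against the trend towards lower numbers with shorter side groups seen among compounds 1, 2 and 3. The data shown offer no measurement that explains these differences.

Compound 4 loses the oxygen and shortens the side group together, so the two changes cannot be separated. As far as these compounds go, the effect of an amine in place of that oxygen also remains open.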